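The source may report more compounds than this note shows. Statements on the series, on what has been measured and on what is new or still open speak of the compounds shown alone.

The measured compounds, with their results in a functional assay on A-375 cells (Homo sapiens) for antiproliferative activity, read by MTT assay, with a stated time of 48 h; a lower number here means a stronger inhibitor of growth, a higher number a weaker inhibitor of growth:

Compound 1, `S=C(Nc1ccccc1)N1N=C(c2ccccc2)CC1c1ccc2c(c1)OCCO2`, gives 1850 nM.
Compound 2, `Cc1ccc(C2=NN(C(=S)Nc3ccccc3)C(c3ccc4c(c3)OCCO4)C2)cc1`, gives 6320 nM.
Compound 3, `S=C(Nc1ccccc1)N1N=C(c2cccc(Cl)c2)CC1c1ccc2c(c1)OCCO2`, gives only a limit, > 200000 nM, and no number.

Compound 3 thus stands at the weak end of the three, where the limit of > 200000 nM in this assay, at which 1 of the 3 values shown sits, sits. The step to compound 4, `Cc1ccc(C2=NN(C(=S)Nc3ccccc3)C(c3ccc4c(c3)OCCO4)C2)cc1C`, is 3,4-dimethylphenyl in place of 3-chlorophenyl on a carbon with a double bond to nitrogen. Among the compounds with values here, two measured steps bear on it. Adding a methyl to the phenyl ring gave a 3.4-fold higher number from compound 1 to compound 2 (0.53 log units; beyond the scatter), a modest loss. Exchanging the same phenyl for the chlorinated one gave an at least 100-fold higher number from compound 1 to compound 3 (2.03 log units; beyond the scatter), a large loss, and the reverse reading runs through an at least 31-fold higher number from compound 2 to compound 3 (1.50 log units; beyond the scatter). Compound 4 carries two methyl groups on that ring and no chlorine, so it is expected to sit near compound 2, perhaps a little weaker if the second methyl costs as the first did. The expected step is therefore a large fall in this assay, an at least 16-fold lower number from compound 3 to compound 4 (1.22 log units; beyond the scatter). The estimate for compound 4 is 12000 nM, within 3000 nM to 60000 nM.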

Compound 4, concentration for 50% growth inhibition: 61300 nM
For compound 4 the middle estimate is 5.1-fold (0.71 log units) below the measured one; the measured number lies above the stated range.
By their numbers in this assay, from the lowest: compound 1; then compound 2; then compound 4. At a limit, above all of these: compound 3.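

Going from the single methyl of compound 2 to the 3,4-dimethylphenyl group costs more growth inhibition in this assay, with a 9.7-fold higher number from compound 2 to compound 4 (0.99 log units; beyond the scatter), so the loss at this position did not end with the first methyl. Against the unsubstituted phenyl, the change gives a 33-fold higher number from compound 1 to compound 4 (1.52 log units; beyond the scatter), which shows that a ring without chlorine can also lose much of its activity, although an at least 3.2-fold lower number from compound 3 to compound 4 (0.51 log units; beyond the scatter) keeps 3,4-dimethylphenyl ahead of 3-chlorophenyl. Compound 3 still has only a limit and no number: the limit of > 200000 nM in this assay, at which 1 of the 4 values shown sits.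

The compounds shown leave open whether a fluorine, a methoxy group or a hydroxyl on this ring would behave like methyl, or whether a pyridine ring in place of the phenyl would do better. Going by these compounds, whether any substituent here can improve on the plain phenyl of compound 1 also remains open.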